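The compounds below may be only part of what the source reports. "The series", "measured", "known", "first", "only" and "open" are said of these compounds alone.

Measured so far in a functional assay on 1A9 cells (Homo sapiens) for cytotoxicity; a higher number here means that more compound is needed for the effect, a lower number that less compound is needed:
- compound 1 `CCc1ccc(/C=C/C(O)=C2/C(=O)C(C)=C(OC)C(C)(C)C2=O)cc1`: 5.3 ug/mL
- compound 2 `CCC1=C(OC)C(CC)(CC)C(=O)C(C(=O)/C=C/c2ccccc2)=C1O`: 2.8 ug/mL
- compound 3 `CCC1=C(OC)C(CC)(CC)C(=O)C(C(=O)/C=C/c2ccc(C)cc2)=C1O`: 4.3 ug/mL

In this assay, compound 3 gives 4.3 ug/mL, which lies within the usual scatter of the values of both compound 1 and compound 2. Next comes compound 4 `CCC1=C(OC)C(CC)(CC)C(=O)C(C(=O)/C=C/c2ccc(CC)cc2)=C1O`, which has not yet been measured. The change is methyl in place of hydrogen on a saturated chain carbon bound to an aromatic carbon, which turns methyl to ethyl, or 4-methylphenyl to 4-ethylphenyl.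

Within the data shown here, one measured step bears on this: a 1.5-fold higher number from compound 2 to compound 3 (0.19 log units; within the scatter). It also adds a methyl, though on an aromatic carbon rather than on a saturated chain carbon, and it stays within the scatter. The 4-ethylphenyl group already appears in compound 1, on a different core, with 5.3 ug/mL. Neither observation points to a real shift, so no step beyond the scatter is expected in this assay. The estimate is a 1.0-fold higher number from compound 3 to compound 4 (0.02 log units; within the scatter). For compound 4, the expected value is 4.5 ug/mL, with an estimated range of 2.5 ug/mL to 8 ug/mL.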

Compound 4, concentration for half-maximal effect: 3.8 ug/mL
Beside the measured number, compound 4's estimate is 1.2-fold (0.07 log units) above it, and the stated range covers the measured number.
By their numbers in this assay, from the lowest: compounds 2, 4, 3 and 1 (each within the scatter of the next).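

In this assay, the change from 4-methylphenyl to 4-ethylphenyl gives a 1.1-fold lower number from compound 3 to compound 4 (0.05 log units; within the scatter) and so shows that adding methyl on this saturated chain carbon bound to an aromatic carbon has no readable effect. Measured against the compound with only hydrogen at this place, the whole ethyl group gives a 1.4-fold higher number from compound 2 to compound 4 (0.13 log units; within the scatter), so the earlier finding for methyl on an aromatic carbon now extends to this slightly longer group. No measurement at hand offers an explanation for these small steps.

The compounds shown leave open whether a longer chain such as hexyl, or a different kind of group such as an amine or a carboxylic acid, would produce a step beyond the scatter at this place. They also leave open whether a step of this kind would stay as small on the core of compound 1.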